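Pyrazole diester coumarin series: HeLa cytotoxicity notes

The source may hold more compounds than are shown below. What is called first, only, known or untested is meant among the compounds shown, and "the series" means these compounds.

Measured compounds:
compound 1, `COC(=O)c1c(-c2cc3ccccc3oc2=O)nn(-c2ccccc2)c1C(=O)OC`, 35000 nM in a functional assay on HeLa cells (Homo sapiens) for cytotoxicity, read by MTT assay, with a stated time of 48 h; on this read-out lower numbers stand for stronger inhibition and higher numbers for weaker inhibition
compound 2, `COC(=O)c1c(-c2cc3ccccc3oc2=O)nn(-c2cccc(C)c2)c1C(=O)OC`, 45000 nM
compound 3, `CCOC(=O)c1c(-c2cc3cc(OC)ccc3oc2=O)nn(-c2ccccc2)c1C(=O)OCC`, 145000 nM

Compound 1 and compound 2 differ by methyl in place of hydrogen on an aromatic carbon; the step of a 1.3-fold higher number from compound 1 to compound 2 (0.11 log units; within the scatter) is small, so the two numbers show no order. Compound 3 stands apart: its number is the highest of the three and lies beyond the scatter from both compound 1 and compound 2. The difference between the core of compound 3 and the core of compound 1 is not broken down here.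

Compound 4, `CCOC(=O)c1c(-c2cc3cc(OC)ccc3oc2=O)nn(-c2cccc(C)c2)c1C(=O)OCC`, is not yet measured. It differs from compound 3 by methyl in place of hydrogen on an aromatic carbon, the same kind of change as that from compound 1 to compound 2. Since that earlier step stayed within the scatter, the step of a 1.2-fold higher number from compound 3 to compound 4 (0.09 log units; within the scatter) is expected to be of similar size, resting on compound 3 at 145000 nM as the starting point. For compound 4 the expected value in this assay is 180000 nM, with a likely range from 90000 nM to 400000 nM.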

Compound 4, half-maximal inhibitory concentration: 155000 nM
Compound 4: middle estimate off by 1.2-fold (0.06 log units), on the high side; measured number inside the range.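

In this assay, exchanging phenyl for 3-methylphenyl on the core of compound 3 gives a 1.1-fold higher number from compound 3 to compound 4 (0.03 log units; within the scatter), so the two numbers show no order. Set beside the earlier step, the change behaves alike on both cores: the same change on two cores in this assay, a 1.3-fold higher number (0.11 log units; within the scatter) from compound 1 to compound 2 and a 1.1-fold higher number (0.03 log units; within the scatter) from compound 3 to compound 4, 1.2-fold (0.08 log units) apart, within the scatter of two such steps. This shows that, on these two cores, methyl in place of hydrogen on this aromatic carbon leaves the number within the scatter; it does not give the change an effect of definite size or direction, and it does not show that the same would hold on a third core.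

The compounds shown leave open whether a group other than methyl at this place on the phenyl, such as an amine or a carboxylic acid, would move the number beyond the scatter on either core. They also leave open how the methoxy group and the ethyl esters each contribute to the gap between the two cores, since those two features change together here.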